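The source may hold more compounds than are shown below. What is called first, only, known or untested is meant among the compounds shown, and "the series" means these compounds.

Three compounds share one core and differ only in the aryl group attached to it. Compound 1 `CCCCN(CC)c1cc(C)nc2c1NC(=O)CN2c1ccc(Br)cc1Cl` was entered in an assay on HEK-293T cells for displacement of a labelled ligand from corticotropin-releasing factor receptor 2 (Homo sapiens), read by scintillation counting, with a stated time of 2 h, tested at 1 uM (on this read-out higher numbers stand for more inhibition at the one concentration tested (going by the name of the read-out) and lower numbers for less inhibition), and compound 1 gives "not determined" (no result reported), with no result reported. Compound 2 `CCCCN(CC)c1cc(C)nc2c1NC(=O)CN2c1ccc(Cl)cc1Br` was entered in the same assay and compound 2 gives "not determined" (no result reported), again with no result reported. Compound 3 `CCCCN(CC)c1cc(C)nc2c1NC(=O)CN2c1ccc(Br)cc1C` is therefore the only one of the set with a number: in this assay compound 3 gives 5.9%, a small degree of inhibition at the single concentration tested, and it stands alone, with nothing measured to compare it against. Within the data shown here, no step between two measured compounds is available here.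

Compound 4 `CCCCN(CC)c1cc(C)nc2c1NC(=O)CN2c1ccc(Br)cc1CC` differs from compound 3 by methyl in place of hydrogen on a saturated chain carbon bound to an aromatic carbon. This is a small addition on the 4-bromo-2-methylphenyl group, turning it into a 4-bromo-2-ethylphenyl group. With a single measured number to start from and so small a change, the expected step is modest, in no clear direction, and not beyond the usual scatter. The step of a number 2.1 percentage points higher from compound 3 to compound 4 (within the scatter) that this estimate means is expected to be small. Compound 4 is expected to give about 8% in this assay, with a range from 0% to 25%.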

Compound 4, a percentage reported as inhibition, at one concentration (the size of the read-out at that concentration, not a potency): 2.1%
Beside the measured number, compound 4's estimate is 5.9 percentage points above it; the range from low to high includes it.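

Among these compounds, replacing hydrogen with methyl on this saturated chain carbon gives the first step that can be read in this assay: a number 3.8 percentage points lower from compound 3 to compound 4 (within the scatter). The 4-bromo-2-methylphenyl and 4-bromo-2-ethylphenyl groups therefore cannot be told apart on this read-out, and both compounds show little inhibition at the one concentration tested, so this small extension of the chain opens no measurable difference. Nothing in the available data offers an explanation for this result.

Since the step lies within the scatter, it gives no direction for further changes at this position. As far as these compounds go, it remains open whether a longer chain such as propyl, or a more different group such as an amine or a carboxylic acid, would give a result clearly outside the scatter of compound 3.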